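A few compounds are considered here, and "the series" means these few. Any claim that something is new, unique, unknown or untested is made for them only; others in the source may bear on it.

Measured in a functional assay on MCF7 cells (Homo sapiens) for cytotoxicity, read by MTT assay, with a stated time of 48 h; a lower number here means a stronger inhibitor, a higher number a weaker inhibitor:
compound 1 `C/C(=N\NC(=S)Nc1ccc(F)cc1)c1ccccn1`, 1.2 nM
compound 2 `C/C(=N\NC(=S)Nc1ccc(I)cc1)c1ccccn1`, 6.61 nM
compound 3 `C/C(=N/NC(=S)Nc1ccc([N+](=O)[O-])cc1)c1ccccn1`, 52 nM

Compound 3 gives the highest number of the three in this assay, beyond the scatter from both compound 2 and compound 1. Compound 4 `C/C(=N\NC(=S)Nc1ccc([N+](=O)[O-])cc1)c1ccccn1` is the counterpart of compound 3: the two compounds have the same atoms and bonds and differ only in configuration as drawn: 1 of 1 stereo elements differ; a double bond is drawn Z in compound 3 and E in compound 4. Among the measured compounds shown here, the one measured step, a 5.5-fold higher number from compound 1 to compound 2 (0.74 log units; beyond the scatter), concerns iodo in place of fluoro on an aromatic carbon and does not bear on a change of configuration; no measured pair informs this step. With identical atoms and bonds, no step beyond the scatter is expected, so compound 4 is expected to give about a 1.0-fold lower number from compound 3 to compound 4 (0.02 log units; within the scatter). Compound 4 is estimated at 50 nM, between 15 nM and 170 nM.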

Compound 4, half-maximal inhibitory concentration: 52 nM
For compound 4 the middle estimate is 1.0-fold (0.02 log units) below the measured one, and the stated range covers the measured number.
By their numbers in this assay, from the lowest: compound 1; then compound 2; then compounds 3 and 4 (each within the scatter of the next).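

In this assay, the drawn configuration of the double bond makes no readable difference for the nitro pair, with no change at the digits printed from compound 3 to compound 4 (within the scatter). Compound 4 is drawn the same way as the halogen compounds, so the aromatic substituent can now be compared at one configuration: nitro in place of iodo gives a 7.9-fold higher number from compound 2 to compound 4 (0.90 log units; beyond the scatter), and nitro in place of fluoro gives a 43-fold higher number from compound 1 to compound 4 (1.64 log units; beyond the scatter). The reading on configuration rests on a single clean pair: the fact that compounds 3 and 4 differ only in the configuration as drawn

As far as these compounds go, whether configuration is equally silent for the fluoro and iodo compounds stays open. So does how an amine or a carboxylic acid on the same aromatic carbon would read in this assay.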